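Swapping the Aryl Amide on a Cyclopropane Dicarboxamide

The source may report more compounds than this note shows. Statements on the series, on what has been measured and on what is new or still open speak of the compounds shown alone.

Compound 1 `CN(C)C(=O)c1cc2cnc(Nc3ccc(NC(=O)C4(C(=O)Nc5ccc(Cl)c(C(F)(F)F)c5)CC4)cc3)nc2n1C1CCCC1` was tested in a functional assay on NCI-H1299 cells (Homo sapiens) for inhibition, read by CCK-8 assay, with a stated time of 72 h, tested at 1 uM (on this read-out lower numbers stand for less inhibition of growth and higher numbers for more inhibition of growth at the one concentration tested), where compound 1 gives 39.5%. Compound 2 `Nc1ccc(NC(=O)C2(C(=O)Nc3ccc(F)cc3)CC2)cc1F` gives 46.2% in this assay, and the two values lie within the scatter of each other. Compound 2 differs from compound 1 in more than one place, so the two numbers stand side by side without any computed step between them. Compound 3 `CN(C)C(=O)c1cc2cnc(Nc3ccc(NC(=O)C4(C(=O)Nc5ccc(F)cc5)CC4)cc3)nc2n1C1CCCC1` has not yet been measured. It differs from compound 1 in a single place: 4-fluorophenyl in place of 4-chloro-3-(trifluoromethyl)phenyl on an amide-type nitrogen. Within the data shown here, no measured pair shows this change on its own, so the expectation rests on the change itself and on compound 2, which carries the same 4-fluorophenyl group on its amide-type nitrogen and gives 46.2%. The expected step is a number 1.5 percentage points higher from compound 1 to compound 3 (within the scatter), a change no larger than the usual scatter. Compound 3 is estimated at 41%, within 26% to 56%.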

Compound 3, percent growth inhibition at one concentration: 93.3%
Compound 3: the middle estimate sits 52.3 percentage points below what was measured; measured number above the stated range.
By their numbers in this assay, from the lowest: compounds 1 and 2 (each within the scatter of the next); then compound 3.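

The aryl group on this amide-type nitrogen has a large effect on the number in this assay: with the rest of compound 1 unchanged, 4-fluorophenyl in place of 4-chloro-3-(trifluoromethyl)phenyl gives a number 53.8 percentage points higher from compound 1 to compound 3 (beyond the scatter) on this single change. The two groups share one six-membered aromatic ring of carbon only and carry no net charge, so they differ only in what is attached to that ring. Among these compounds, nothing measured here explains why this change moves the number so far.

The compounds shown do not separate the loss of the chlorine from the loss of the trifluoromethyl, and they leave open how a plain phenyl or a pyridyl group on the same nitrogen would read. As far as these compounds go, each number also comes from one concentration in one cell line, and whether the gain holds at other concentrations or in other cells remains unknown.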